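The compounds below may be only part of what the source reports. "The series", "measured", "known", "first", "only" and "open" are said of these compounds alone.

Two compounds share one core and differ only in the chain that hangs from the oxygen on a saturated carbon. Compound 1 `C=CCc1cc(OC)c(OC(C)C(OCCCCCCCC)c2ccc(O)c(OC)c2)c(OC)c1` carries an octyl group there, and compound 2 `C=CCc1cc(OC)c(OC(C)C(OCCCCCC)c2ccc(O)c(OC)c2)c(OC)c1` a hexyl group. In an assay on HEK293 cells for agonist activity at transient receptor potential cation channel subfamily M member 8 (Homo sapiens), read by fluorescence and calcium flux, with a stated time of 5 min (a higher number here means that more compound is needed for the effect, a lower number that less compound is needed), compound 1 gives 86 nM, while compound 2 gives 329 nM. For the measured compounds named here, the single step between them, a 3.8-fold higher number from compound 1 to compound 2 (0.58 log units; beyond the scatter), is a hydrogen in place of ethyl on a saturated chain carbon, six bonds along the chain from an oxygen on a saturated carbon. Going by the values given here, compound 2 thus stands at the higher of the two numbers measured so far in this assay, the only neighbour being compound 1 at the lower one.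

Compound 3 `C=CCc1cc(OC)c(OC(C)C(OC2CCCCC2)c2ccc(O)c(OC)c2)c(OC)c1` has not been measured yet. It differs from compound 2 by cyclohexyl in place of hexyl on an oxygen on a saturated carbon. Among the compounds with values here, no measured step matches this change; the step from compound 1 to compound 2 concerns chain length alone and is only a loose guide. The carbon count is unchanged, so compound 3 is expected to land near compound 2, a step of a 1.2-fold higher number from compound 2 to compound 3 (0.08 log units; within the scatter) within the scatter. The estimate for compound 3 in this assay is 400 nM, with a range from 130 nM to 1200 nM.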

Compound 3, half-maximal effective concentration: 54 nM
Estimate against measurement, compound 3: 7.4-fold (0.87 log units) above; the whole stated range lies above it.
By their numbers in this assay, from the lowest: compounds 3 and 1 (each within the scatter of the next); then compound 2.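

At this oxygen on a saturated carbon, the carbon count alone does not set the number: replacing hexyl with cyclohexyl gives a 6.1-fold lower number from compound 2 to compound 3 (0.78 log units; beyond the scatter) in this assay, although both groups have the same carbon count. The earlier step, from octyl to hexyl, changed only chain length, so it could not separate the size of the group from whether its carbons form an open chain or a ring. Compared with the longer chain, cyclohexyl gives a 1.6-fold lower number from compound 1 to compound 3 (0.20 log units; within the scatter), so on these numbers the ring and the octyl chain cannot be told apart, even though the hexyl chain stands clearly apart from both.

Nothing available here gives a reason why the ring and the open hexyl chain differ so clearly. From the compounds shown here alone, it remains open whether a smaller ring such as cyclopentyl, a ring holding an amine such as piperidinyl, an aromatic group such as benzyl or a chain longer than octyl would keep, improve or lose this level at the same oxygen.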